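Working notes: 2-ethoxypyridin-3-yl in place of 2-nitrobenzyl

This account rests on a few compounds, and the source may have more. Where it says the series, first, only, none or still open, it means among the compounds named here.

Measured so far in a functional assay on BJAB cells (Homo sapiens) for antiproliferative activity, with a stated time of 4 days; a higher number here means that more compound is needed for the effect, a lower number that less compound is needed:
compound 1 `CCSc1sc(-n2nc(C)c(Cc3ccccc3[N+](=O)[O-])c2C(=O)O)nc1-c1ccc(Cl)c(Cl)c1` gives 59000 nM
compound 2 `Cc1nn(-c2nc(-c3ccc(Cl)c(Cl)c3)c(SC(C)C)s2)c(C(=O)O)c1Cc1ccccc1[N+](=O)[O-]` gives 20000 nM
compound 3 `COC(=O)c1c(Cc2ccccc2[N+](=O)[O-])c(C)nn1-c1nc(-c2ccc(Cl)c(Cl)c2)cs1` gives 377000 nM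

Compound 2 stands lowest of the three numbers in this assay. For the measured compounds named here, its nearest neighbour is compound 1, and the only single-point step measured is a 3.0-fold lower number from compound 1 to compound 2 (0.47 log units; beyond the scatter). Compound 3 lies furthest from compound 2, and their two values alone show that gap.

Compound 4 `CCOc1ncccc1-c1c(C)nn(-c2nc(-c3ccc(Cl)c(Cl)c3)c(SC(C)C)s2)c1C(=O)O` differs from compound 2 by 2-ethoxypyridin-3-yl in place of 2-nitrobenzyl on an aromatic carbon. Going by the values given here, no measured step touches this place: the one step known, a 3.0-fold lower number from compound 1 to compound 2 (0.47 log units; beyond the scatter), changes the chain on the sulfur and says nothing about the group on the five-membered ring. With nothing to anchor direction, the expectation for compound 4 in this assay is a change of a 1.3-fold lower number from compound 2 to compound 4 (0.12 log units; within the scatter), and the range is kept wide. The estimate for compound 4 is 15000 nM. Its lower end for compound 4 is estimated at 2000 nM. Its upper end for compound 4 is estimated at 120000 nM.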

Compound 4, half-maximal effective concentration: 11000 nM
Beside the measured number, compound 4's estimate is 1.4-fold (0.13 log units) above it, and the stated range covers the measured number.
By their numbers in this assay, from the lowest: compounds 4 and 2 (each within the scatter of the next); then compound 1; then compound 3.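

In this assay, 2-ethoxypyridin-3-yl in place of 2-nitrobenzyl on this aromatic carbon gives a 1.8-fold lower number from compound 2 to compound 4 (0.26 log units; within the scatter). For the compounds shown here, this is the first reading at this position, and it shows that, with the carboxy group and the methyl group kept, the nitro-bearing group can be exchanged here without a step beyond the scatter. No measurement at hand offers a cause for this result.

Which part of the new group matters stays open: the ethoxy chain or the ring nitrogen. On these data alone, how an amine, a plain phenyl or a longer alkoxy chain would read at this carbon also remains open.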